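The source may report more compounds than this note shows. Statements on the series, on what has been measured and on what is new or still open speak of the compounds shown alone.

Measured so far:
- compound 1, `Nc1cc(N)c2nc(-c3ccccc3)c(Oc3ccc(Cl)c(Cl)c3)nc2c1` — in a functional assay on OVCAR-5 cells (Homo sapiens) for inhibition, read by sulforhodamine B assay, with a stated time of 48 h (on this read-out lower numbers stand for stronger inhibition of growth and higher numbers for weaker inhibition of growth), compound 1 gives 58900 nM
- compound 2, `CCOC(=O)[C@H](CCC(=O)O)NC(=O)c1ccc(CNc2nc3cc(N)cc(N)c3nc2-c2ccccc2)cc1` — for compound 2 only a limit is reported, < 100000 nM
- compound 3, `COc1cc(CNc2nc3cc(N)cc(N)c3nc2-c2ccccc2)cc(OC)c1OC` — for compound 3 only a limit is reported, < 50200 nM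

Within the data shown here, compound 1 thus stands as the only compound with an actual number; the other two results are limits of the assay rather than values, one at the limit of < 100000 nM in this assay, at which 1 of the 3 values shown sits, and one at the limit of < 50200 nM in this assay, at which 1 of the 3 values shown sits. Compound 4, `Nc1cc(N)c2nc(-c3ccccc3)c(Oc3ccc(F)cc3)nc2c1`, differs from compound 1 in one place: 4-fluorophenyl in place of 3,4-dichlorophenyl on an oxygen on an aromatic ring. Among the measured compounds shown here, no measured pair shows what such a change does here, so the expectation for the step from compound 1 to compound 4 in this assay is a shift no larger than the usual scatter, in no firm direction, a 1.2-fold higher number from compound 1 to compound 4 (0.07 log units; within the scatter). For compound 4 the estimated value is 70000 nM, within a range from 30000 nM to 150000 nM.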

Compound 4, concentration for total growth inhibition: 47900 nM
For compound 4 the middle estimate is 1.5-fold (0.16 log units) above the measured one; measured number inside the range.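

In this assay, putting 4-fluorophenyl in place of 3,4-dichlorophenyl on the oxygen gives a 1.2-fold lower number from compound 1 to compound 4 (0.09 log units; within the scatter), so the two compounds cannot be told apart. Among these compounds, this is the only measured pair that changes this place on the shared core, and it shows that this exchange of ring substituents leaves the read-out within the usual scatter. Nothing in the data shown bears on why the step is this size. Still open, going by these compounds, is whether a different group on this oxygen, such as a plain phenyl or a phenyl carrying a nitrile, would shift the number beyond the scatter.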